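The source may hold more compounds than are shown below. What is called first, only, known or untested is meant among the compounds shown, and "the series" means these compounds.

Compound 1, `CC(C(=O)N1CC2CC2C1)N1CCN(S(=O)(=O)c2ccc(C(C)(C)C)cc2)CC1`, gives > 40000 nM in an ADME assay on HepG2 cells (Homo sapiens) for inhibition, with a stated time of 48 h; on this read-out higher numbers stand for an effect only at larger amounts of compound and lower numbers for an effect already at smaller amounts; this is a limit of the assay and not a number. Compound 2, `C[C@H](C(=O)N1CCCCC1)N1CCN(S(=O)(=O)c2ccc(C(C)(C)C)cc2)CC1`, gives > 40000 nM in this assay; this too is a limit, not a number. Compound 2 therefore stands at the edge of what this assay reports, and the other value shown sits at the same edge, as the limit of > 40000 nM in this assay, at which 2 of the 2 values shown sit, records. Among the measured compounds shown here, no two measured compounds differ in one place, so no measured step is available.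

Compound 3, `C[C@@H](C(=O)N1CCCCC1)N1CCN(S(=O)(=O)c2ccc(C(C)(C)C)cc2)CC1`, is the next compound. It differs from compound 2 as follows: the two compounds have the same atoms and bonds and differ only in configuration as drawn: 1 of 1 stereo elements differ; a stereocentre at a saturated chain carbon is drawn R in compound 2 and S in compound 3. For the measured compounds named here, with compound 2 at the limit and no measured step to lean on, the change from compound 2 to compound 3 is expected to bring no shift beyond the scatter, so that the estimate for compound 3 is 40000 nM, in the range from 20000 nM to 80000 nM, which means an expected step of a number no higher from compound 2 to compound 3 (the limit leaves the size open).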

Compound 3, half-maximal effective concentration: > 40000 nM
Compound 3: a limit, no number (the forecaster's own chance of this, stated with the estimate: 85%); the middle value sits exactly at the limit.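

Compound 2 and compound 3 both stand at a limit of this assay and not at a number, and the step between them cannot be read. The compounds shown leave open whether the drawn configuration at the saturated chain carbon makes any difference in this assay, and at what concentration any of the three compounds would show an effect.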